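The source may hold more compounds than are shown below. What is called first, only, known or untested is meant among the compounds shown, and "the series" means these compounds.

Working notes on the propargylamine series. Among the measured compounds shown here, compound 1, `C#CCNC1CCc2c(SCCc3cccc(C)c3)cccc21`, is the only compound with a full number in an assay on isolated protein for inhibition of Amine oxidase [flavin-containing] B (Homo sapiens) (a higher number here means a weaker inhibitor, a lower number a stronger inhibitor), where compound 1 gives 0.35 nM. Compound 2, `C#CCNC1CCc2c(SCc3cccc(C)c3)cccc21`, is reported in this assay only as a limit, and compound 2 gives > 100000 nM, which is the limit itself and not a number (the limit of > 100000 nM in this assay, at which 1 of the 2 values shown sits). Compound 3, `C#CCNC1CCc2c(SCCc3cccc(Br)c3)cccc21`, has not yet been measured. Compound 3 differs from compound 1 by bromo in place of methyl on an aromatic carbon; the same difference, cut one bond further out, reads 3-methylphenyl to 3-bromophenyl. For the measured compounds named here, no step between two measured compounds with this kind of change is available, so the expected step rests on the change alone. The expected step from compound 1 to compound 3 in this assay is a 1.4-fold higher number from compound 1 to compound 3 (0.15 log units; within the scatter), a shift not beyond the scatter. Compound 3 is therefore estimated at 0.5 nM, with a range from 0.15 nM to 2.5 nM.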

Compound 3, half-maximal inhibitory concentration: 30500 nM
Estimate against measurement, compound 3: 61000-fold (4.79 log units) below; the whole stated range lies below it.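

In this assay, the 3-methylphenyl to 3-bromophenyl change is far from neutral: an 87000-fold higher number from compound 1 to compound 3 (4.94 log units; beyond the scatter). Among the compounds shown here, one heavy atom is exchanged for one heavy atom, with no change in the counts of rings, hydrogen-bond donors or acceptors, or net charge, so the earlier compounds, which differ only in the chain, gave no sign that this place on the aromatic ring could matter so much. The data shown give no measured property that accounts for the size of this step.

On these data alone, it remains open whether the large step is specific to bromo or extends to other replacements of methyl at this place, such as hydrogen, fluoro, chloro or methoxy. Also open, as far as these compounds go, is whether moving methyl or bromo elsewhere on the ring, or lengthening the chain to a propyl linker, would change the picture.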